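The source may report more compounds than this note shows. Statements on the series, on what has been measured and on what is new or still open speak of the compounds shown alone.

Measured compounds in a functional assay on PC-3 cells (Homo sapiens) for cytotoxicity, read by MTT assay, with a stated time of 48 h; on this read-out higher numbers stand for weaker inhibition and lower numbers for stronger inhibition:
compound 1 `COc1cc(-c2nnc3n2NC(c2ccco2)C(C(=O)c2ccc(Br)cc2)S3)cc(OC)c1OC`, compound 1 gives 36400 nM
compound 2 `COc1cc(-c2nnc3n2NC(c2ccco2)C(C(=O)c2ccc(F)cc2)S3)cc(OC)c1OC`, compound 2 gives 27700 nM
compound 3 `COc1cc(-c2nnc3n2NC(c2cccs2)C(C(=O)c2ccccc2)S3)cc(OC)c1OC`, compound 3 gives 86300 nM

Compound 3 stands with the highest number of the three in this assay; compound 1 is nearest to it and compound 2 furthest, both beyond the scatter. Among the measured compounds shown here, the only single-point step measured so far is a 1.3-fold lower number from compound 1 to compound 2 (0.12 log units; within the scatter), a change on the benzoyl group that does not touch the five-membered ring at the saturated ring carbon, and it says nothing directly about the change to compound 4.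

Compound 4 `COc1cc(-c2nnc3n2NC(c2ccco2)C(C(=O)c2ccccc2)S3)cc(OC)c1OC` arises from compound 3 by furan-2-yl in place of thiophen-2-yl on a saturated ring carbon. For the measured compounds named here, no measured pair isolates this exchange. What the numbers show is that compounds 1 and 2, both carrying furan-2-yl, sit well below compound 3 in this assay, while compound 4 also differs from them at the benzoyl group. On this basis a lower number is expected for compound 4, with the step of a 2.1-fold lower number from compound 3 to compound 4 (0.31 log units; beyond the scatter) treated as uncertain in size. The estimate for compound 4 in this assay is 42000 nM, within 20000 nM to 90000 nM.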

Compound 4, half-maximal inhibitory concentration: 64300 nM
The estimate for compound 4 lay 1.5-fold (0.18 log units) below the measured number, and the stated range covers the measured number.
By their numbers in this assay, from the lowest: compounds 2, 1, 4 and 3 (each within the scatter of the next, the first and the last beyond it).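

In this assay, the step for furan-2-yl in place of thiophen-2-yl on the saturated ring carbon, a 1.3-fold lower number from compound 3 to compound 4 (0.13 log units; within the scatter), shows that this exchange alone barely moves the number with an otherwise unsubstituted benzoyl group. Furan-2-yl held constant also gives the first reading of the aromatic substituent: hydrogen in place of fluoro gives a 2.3-fold higher number from compound 2 to compound 4 (0.37 log units; beyond the scatter), whereas hydrogen in place of bromo gives a 1.8-fold higher number from compound 1 to compound 4 (0.25 log units; within the scatter). No supporting evidence bears on these steps, and they remain observations without an assigned cause.

The compounds shown leave open whether phenyl or methyl on the saturated ring carbon would shift the number beyond the scatter. Also open, from the compounds shown here alone, is whether fluoro or bromo on the benzoyl group would act alongside thiophen-2-yl as alongside furan-2-yl.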